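Aryl for Benzyl on the Triazole Nitrogen of Compound 2

The source may hold more compounds than are shown below. What is called first, only, known or untested is meant among the compounds shown, and "the series" means these compounds.

Measured compounds:
compound 1 `CCCCCCc1cc2cn(Cc3cn(Cc4ccccc4)nn3)c(=O)nc2o1`: 93500 nM
compound 2 `CCCCCCC#Cc1c(CCCCCC)oc2nc(=O)n(Cc3cn(Cc4ccccc4)nn3)cc12`: 32600 nM
compound 3 `O=c1nc2oc(C3CC3)cc2cn1Cc1cn(-c2ccc(Cl)cc2)nn1`: > 100000 nM, which is a limit of the assay, not a number

In a functional assay on SW-620 cells (Homo sapiens) for antiproliferative activity, read by MTT assay, with a stated time of 72 h (a lower number here means a stronger inhibitor, a higher number a weaker inhibitor), compound 2 gives 32600 nM, the lowest of the two numbers shown. Among the compounds with values here, the single measured step, a 2.9-fold lower number from compound 1 to compound 2 (0.46 log units; beyond the scatter), is the only change with a known size. Compound 3 gives only a limit, > 100000 nM.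

Compound 4 `CCCCCCC#Cc1c(CCCCCC)oc2nc(=O)n(Cc3cn(-c4ccc(F)cc4)nn3)cc12` carries 4-fluorophenyl in place of benzyl on an aromatic nitrogen. Within the data shown here, no measured step alters the group on that ring nitrogen, so none bears directly on this change; compound 3 also bears an aryl group there but differs in other places as well, and its value is a limit. The expected step is therefore a 1.5-fold higher number from compound 2 to compound 4 (0.19 log units; within the scatter), with compound 4 estimated at 50000 nM, ranging from 15000 nM to 150000 nM.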

Compound 4, half-maximal inhibitory concentration: > 100000 nM
Compound 4 was reported as a limit; the forecaster's own chance of this, stated with the estimate: 30%; at least 2.0-fold (0.30 log units) between middle value and limit.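

In this assay, within the data shown here, this is the first measured change on this triazole nitrogen, and 4-fluorophenyl in place of benzyl gives an at least 3.0-fold higher number from compound 2 to compound 4 (0.48 log units; beyond the scatter). So the group at this position does matter in this series, and with the rest of the molecule unchanged, benzyl gives the lower number of the pair. The full size of the step stays unknown because compound 4 sits at a limit of the assay, not at a number: the limit of > 100000 nM in this assay, at which 2 of the 4 values shown sit.

Going by these compounds, it remains open whether the fluorine or the missing carbon link between ring and nitrogen accounts for the step. Plain phenyl and 4-fluorobenzyl on that nitrogen would separate the two.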